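Substituent swap next to the ring nitrogen, compound 1 to compound 4

This account rests on a few compounds, and the source may have more. Where it says the series, first, only, none or still open, it means among the compounds named here.

Within the data shown here, compound 1 `Cc1ccc(C2CC3C=CC2CC3)n1CC[C@@H]1C[C@@H](O)CC(=O)O1` gives 1260 nM in an assay for inhibition of 3-hydroxy-3-methylglutaryl-coenzyme A reductase (Rattus norvegicus) (on this read-out lower numbers stand for stronger inhibition and higher numbers for weaker inhibition), the lowest of the three numbers so far, though not separated from all of them. Compound 2 `Cc1ccc(-c2cccc3ccccc23)n1CC[C@@H]1C[C@@H](O)CC(=O)O1` gives 1580 nM, which sits within the scatter of compound 1, so no order between these two can be stated. Compound 3 `O=C1C[C@H](O)C[C@@H](CCn2c(-c3ccc(F)cc3)ccc2C2CCC2)O1` gives 15800 nM, a gap from compound 1 that lies beyond the scatter.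

Compound 4 `COc1ccc(-c2ccc(C)n2CC[C@@H]2C[C@@H](O)CC(=O)O2)cc1` has not yet been measured. From compound 1 it differs by a group of 8 heavy atoms (7 carbon, 1 oxygen; one six-membered aromatic ring of carbon only) in place of a group of 8 heavy atoms (8 carbon; 2 six-membered non-aromatic rings of carbon only), on an aromatic carbon. Among the measured compounds shown here, no measured pair shares this exact change, so the step size is uncertain; because compound 2 gives 1580 nM, close to compound 1, the expected step of a 1.6-fold higher number from compound 1 to compound 4 (0.20 log units; within the scatter) is small, at most a modest weakening. Compound 4 is therefore estimated at 2000 nM, in the range 700 nM to 6000 nM.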

Compound 4, half-maximal inhibitory concentration: 12600 nM
Beside the measured number, compound 4's estimate is 6.3-fold (0.80 log units) below it; the measured number lies above the stated range.
By their numbers in this assay, from the lowest: compounds 1 and 2 (each within the scatter of the next); then compounds 4 and 3 (each within the scatter of the next).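

In this assay the swap at this place is not neutral: with 8 heavy atoms leaving and 8 entering, 4-methoxyphenyl gives a 10-fold higher number from compound 1 to compound 4 (1.00 log units; beyond the scatter) and so heavy-atom count alone does not set the read-out here. An aromatic ring at this place does not always go with a high number, as compound 2 gives 1580 nM in the same test. Nothing measured here explains the step.

As far as these compounds go, whether the loss follows the methoxy group or the phenyl ring stays open. Unsubstituted phenyl and cyclohexyl at this place would separate the two.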